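Cyclopentyloxy in place of (cyclopropylmethyl)amino: working notes

This account rests on a few compounds, and the source may have more. Where it says the series, first, only, none or still open, it means among the compounds named here.

Measured so far in a physicochemical assay for solubility (on this read-out lower numbers stand for lower solubility and higher numbers for higher solubility), for the series:
- compound 1 (`C[C@@H]1CN(c2c(C#N)c(C(F)F)nn2-c2ccc(S(C)(=O)=O)cn2)[C@H](C)CO1`) gives > 200 ug/mL (a limit of the assay)
- compound 2 (`CS(=O)(=O)c1ccc(-n2nc(C(F)(F)F)cc2NCC2CC2)nc1`) gives "not determined" (no result reported) (no result)

Compound 2 has only "not determined" (no result reported) in this assay and so has no number to place it by. Within the data shown here, compound 1 holds the only other reading, and that is a limit of the assay and not a number (the limit of > 200 ug/mL in this assay, at which 1 of the 2 values shown sits).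

Compound 3 (`CS(=O)(=O)c1ccc(-n2nc(C(F)(F)F)cc2OC2CCCC2)nc1`) is still unmeasured. The change cyclopentyloxy in place of (cyclopropylmethyl)amino on an aromatic carbon puts cyclopentyloxy in place of (cyclopropylmethyl)amino on an aromatic carbon, next to the ring nitrogen.

Among the measured compounds shown here, no measured step bears on this change, so its size in this assay cannot be read from the data. Compound 3 is expected to fall well short of the limit seen for compound 1, by a gap beyond the scatter. The estimated value for compound 3 is 25 ug/mL with an expected range from 4 ug/mL to 120 ug/mL on this estimate.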

Compound 3, solubility: 50 ug/mL
Beside the measured number, compound 3's estimate is 2.0-fold (0.30 log units) below it; low and high end bracket the measured number.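

In this assay, among these compounds, no new step can be read from compound 3: compound 2, the one compound differing from it in one place, gives no number to compare. The compounds shown leave open how large the change from (cyclopropylmethyl)amino to cyclopentyloxy is on this read-out.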